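Compound 3: same atoms, joined differently

The source may report more compounds than this note shows. Statements on the series, on what has been measured and on what is new or still open speak of the compounds shown alone.

In a functional assay on MCF7 cells (Homo sapiens) for antiproliferative activity, read by MTT assay, with stated times of 24 h and 72 h (on this read-out higher numbers stand for weaker inhibition and lower numbers for stronger inhibition), compound 1 `COc1ccc([C@@H]2[C@H](Oc3ccccc3)C(=O)N2c2cc(OC)c(OC)c(OC)c2)cc1OC` gives 26000 nM and compound 2 `COc1ccc([C@@H]2[C@H](Oc3ccccc3)C(=O)N2c2cc(OC)c(OC)c(OC)c2)c(N)c1O` gives 19000 nM. These two values lie within the scatter of each other, so compound 2 stands level with compound 1 on the numbers available.

Compound 3 `COc1cc(N)c([C@@H]2[C@H](Oc3ccccc3)C(=O)N2c2cc(OC)c(OC)c(OC)c2)cc1O` has not yet been measured in this assay. Its difference from compound 2 is a group of 10 heavy atoms (7 carbon, 1 nitrogen, 2 oxygen; one six-membered aromatic ring of carbon only) in place of a group of 10 heavy atoms (7 carbon, 1 nitrogen, 2 oxygen; one six-membered aromatic ring of carbon only), on a saturated ring carbon. The two have the same atoms, joined differently, and the exchanged group sits on a saturated ring carbon of a four-membered non-aromatic ring with 1 nitrogen.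

Among the compounds with values here, only one measured step bears on this change: a 1.4-fold lower number from compound 1 to compound 2 (0.14 log units; within the scatter). That step exchanges a group at the same place, but its atoms differ, so it is only an indirect guide. Within the data shown here, no measured pair shows the effect of joining the same atoms differently. The series therefore supports no firm direction, and no step beyond the scatter is expected in this assay. The expected change is small: a 1.1-fold lower number from compound 2 to compound 3 (0.05 log units; within the scatter). For compound 3, the estimated value is 17000 nM, with an expected range from 5000 nM to 45000 nM.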

Compound 3, half-maximal inhibitory concentration: 20000 nM
For compound 3 the middle estimate is 1.2-fold (0.07 log units) below the measured one, and the stated range covers the measured number.
By their numbers in this assay, from the lowest: compounds 2, 3 and 1 (each within the scatter of the next).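

Working notes on this position: in this assay the first pair with the same atoms joined differently gives a 1.1-fold higher number from compound 2 to compound 3 (0.02 log units; within the scatter), so on the saturated ring carbon of the four-membered ring this exchange produces no step that can be told from the scatter. The comparison with the group lacking nitrogen gives a 1.3-fold lower number from compound 1 to compound 3 (0.11 log units; within the scatter) and is also within the scatter, so all three groups shown at this place read level, whether or not the group carries nitrogen and however those atoms are joined among compounds 2 and 3. No independent measurement bears on this result.

The compounds shown leave open whether any group at this carbon can produce a step beyond the scatter, since only six-membered aromatic carbon rings appear here, and a carboxylic acid or a longer chain on that ring would test this more widely. They also leave open how the number responds at the neighbouring ring atom, where an amine in place of the phenoxy group would show whether that position matters more than this one.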